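Compound 3: pyrrolidin-3-yl in place of oxolan-3-yl

This account rests on a few compounds, and the source may have more. Where it says the series, first, only, none or still open, it means among the compounds named here.

In a functional assay on HT-29 cells (Homo sapiens) for inhibition, read by luminescence and CellTiter-Glo, with a stated time of 24 h (a higher number here means that more compound is needed for the effect, a lower number that less compound is needed), compound 1 `CN1C(=S)[C@@H](NC(=O)c2nc(Cc3ccccc3)n(CCCC#N)n2)COc2ccccc21` gives 2400 nM and compound 2 `CN1C(=S)[C@@H](NC(=O)c2nc(Cc3ccccc3)n(C3CCOC3)n2)COc2ccccc21` gives 1580 nM. For the measured compounds named here, compound 2 therefore stands level with compound 1: the only measured step, a 1.5-fold lower number from compound 1 to compound 2 (0.18 log units; within the scatter), lies within the scatter. Compound 3 `CN1C(=S)[C@@H](NC(=O)c2nc(Cc3ccccc3)n(C3CCNC3)n2)COc2ccccc21` carries pyrrolidin-3-yl in place of oxolan-3-yl on an aromatic nitrogen. Going by the values given here, that measured step is the only evidence for a change on this nitrogen, and no measured compound carries pyrrolidin-3-yl. No shift beyond the scatter is expected in this assay, with an estimated 1.1-fold higher number from compound 2 to compound 3 (0.06 log units; within the scatter). For compound 3 the estimated value is 1800 nM, with an expected range of 700 nM to 4500 nM.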

Compound 3, half-maximal effective concentration: 1070 nM
Beside the measured number, compound 3's estimate is 1.7-fold (0.23 log units) above it; measured number inside the range.
By their numbers in this assay, from the lowest: compounds 3, 2 and 1 (each within the scatter of the next, the first and the last beyond it).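

On this aromatic nitrogen, pyrrolidin-3-yl brings a hydrogen-bond donor that oxolan-3-yl lacks, yet the number in this assay does not separate the two (a 1.5-fold lower number from compound 2 to compound 3 (0.17 log units; within the scatter)). Against 3-cyanopropyl, pyrrolidin-3-yl gives the first step at this position that clears the scatter, though only modestly (a 2.2-fold lower number from compound 1 to compound 3 (0.35 log units; beyond the scatter)). No accompanying data offer an explanation for either step.

From the compounds shown here alone, it remains open whether a primary amine on a longer chain or a carboxylic acid at this position would extend the modest step from 3-cyanopropyl.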